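The source may report more compounds than this note shows. Statements on the series, on what has been measured and on what is new or still open speak of the compounds shown alone.

Compound 1 `Brc1cn2ccnc2c(-c2ccc3ncn(C4CCCCC4)c3c2)n1`: 11.5%
Compound 2 `c1cn2cc(-c3ccsc3)nc(-c3ccc4ncn(C5CCCCC5)c4c3)c2n1`: 5.76%

In a functional assay on ACHN cells (Homo sapiens) for inhibition, read by sulforhodamine B assay, with a stated time of 48 h, tested at 10 uM (a lower number here means less inhibition, a higher number more inhibition at the concentration tested (going by the name of the read-out)), compound 2 gives 5.76%, while compound 1 gives 11.5%; the two numbers sit within the scatter of each other, so neither can be placed above the other. Compound 3 `FC(F)(F)c1cccc(-c2cn3ccnc3c(-c3ccc4ncn(C5CCCCC5)c4c3)n2)c1` differs from compound 2 by 3-(trifluoromethyl)phenyl in place of thiophen-3-yl on an aromatic carbon. For the measured compounds named here, the one measured step at this position, a number 5.7 percentage points lower from compound 1 to compound 2 (within the scatter), exchanged one group for another there and stayed within the scatter. On that basis the change to compound 3 is expected to give a number 4.2 percentage points higher from compound 2 to compound 3 (within the scatter), nothing beyond the scatter. Compound 3 is therefore estimated at 10%, range 0% to 28%.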

Compound 3, a percentage reported as inhibition, at one concentration (the size of the read-out at that concentration, not a potency): 0.3%
For compound 3 the middle estimate is 9.7 percentage points above the measured one; the measured number falls inside the stated range.
By their numbers in this assay, from the lowest: compounds 3, 2 and 1 (each within the scatter of the next, the first and the last beyond it).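

The position gives its first step beyond the scatter in this assay, with 3-(trifluoromethyl)phenyl in place of bromo: a number 11.2 percentage points lower from compound 1 to compound 3 (beyond the scatter). The two aromatic groups cannot be ranked against each other, with a number 5.5 percentage points lower from compound 2 to compound 3 (within the scatter) as the step between them. Nothing measured here gives a reason for either step.

On these data alone, whether an amine or a carboxylic acid on this aromatic carbon would give a reading beyond the scatter of compound 1 remains open. So does whether a saturated ring such as morpholine would behave like the aromatic groups.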